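Compound 4 Against the Limit of Compound 2

A few compounds are considered here, and "the series" means these few. Any claim that something is new, unique, unknown or untested is made for them only; others in the source may bear on it.

compound 1 (`CCC(C)=C1C(=O)N(c2ccc(Cl)cc2)N(c2ccc(Cl)cc2)C1=O`): 49200 nM
compound 2 (`CN(C)c1ccc(C=C2C(=O)N(c3ccc(Cl)cc3)N(c3ccc(Cl)cc3)C2=O)cc1`): > 128000 nM
compound 3 (`COc1cc(C=C2C(=O)N(c3ccc(Cl)cc3)N(c3ccc(Cl)cc3)C2=O)cc(OC)c1OC`): 29500 nM

In a functional assay on SMMC-7721 cells (Homo sapiens) for cytotoxicity, read by MTT assay, with a stated time of 72 h (on this read-out higher numbers stand for weaker inhibition and lower numbers for stronger inhibition), compound 2 stands only at the limit > 128000 nM of the assay, with no number to its name. Compound 4 (`COc1cc(C=C2C(=O)N(c3ccc(Cl)cc3)N(c3ccc(Cl)cc3)C2=O)ccc1O`) has not yet been measured. It shares the core of compound 2 but carries 4-hydroxy-3-methoxyphenyl in place of 4-(dimethylamino)phenyl on a double-bonded chain carbon bound to a double-bonded ring carbon, an exchange counted as follows (4-hydroxy-3-methoxyphenyl in place of 4-(dimethylamino)phenyl on a double-bonded chain carbon bound to a double-bonded ring carbon) and the only difference between the two.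

Within the data shown here, no step between measured compounds is available to guide the estimate. In this assay compound 3, which also carries methoxy groups, gives 29500 nM as a measured number, and this value is the main ground for the expectation. The expected step of an at least 4.0-fold lower number from compound 2 to compound 4 (0.60 log units; beyond the scatter) in this assay runs towards stronger inhibition and is expected to lie beyond the scatter. For compound 4 the estimated value is 32000 nM with an expected range from 11000 nM to 90000 nM on this measure.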

Compound 4, half-maximal inhibitory concentration: 64900 nM
The estimate for compound 4 lay 2.0-fold (0.31 log units) below the measured number; measured number inside the range.
By their numbers in this assay, from the lowest: compounds 3, 1 and 4 (each within the scatter of the next, the first and the last beyond it). At a limit, above all of these: compound 2.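

Compound 4 gives this position a measured number where compound 2 offered only a limit, showing that in this assay 4-hydroxy-3-methoxyphenyl on a double-bonded chain carbon bound to a double-bonded ring carbon can be read on the scale. The exchange of 4-(dimethylamino)phenyl for this group gives an at least 1.9-fold lower number from compound 2 to compound 4 (0.29 log units; that floor lies within the scatter), so the printed floor alone does not establish a change beyond the scatter. Compound 2 holds a limit and not a number, which leaves the true size of the step unknown: the limit of > 128000 nM in this assay, at which 1 of the 4 values shown sits.

The compounds shown do not tell whether the hydroxy or the methoxy part of 4-hydroxy-3-methoxyphenyl accounts for the step. They also leave open how an unsubstituted phenyl or a carboxylic acid at this place would read against compound 4.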